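A smaller group on the ring amine nitrogen

A few compounds are considered here, and "the series" means these few. Any claim that something is new, unique, unknown or untested is made for them only; others in the source may bear on it.

Of the compounds shown here, two built on a shared core have been measured in an assay on CHO-K1 cells for displacement of a labelled ligand from melanin-concentrating hormone receptor 1 (Homo sapiens), with a stated time of 2 h; on this read-out lower numbers stand for stronger inhibition and higher numbers for weaker inhibition. Compound 1 `Cc1nc(N2CCC(O)CC2)nc2ccc(NC(=O)COc3ccc(Cl)cc3)cc12` gives 150 nM. Compound 2 `Cc1nc(N2CCN(C3CCOCC3)CC2)nc2ccc(NC(=O)COc3ccc(Cl)cc3)cc12` gives 45 nM in this assay, the lower of the two numbers, and its gap to compound 1 is beyond the scatter. Compound 3 `Cc1nc(N2CCN(C)CC2)nc2ccc(NC(=O)COc3ccc(Cl)cc3)cc12` differs from compound 2 in one place: methyl in place of oxan-4-yl on an amine nitrogen in a ring. Within the data shown here, no measured pair shows what this change does. The step of a 2.0-fold higher number from compound 2 to compound 3 (0.30 log units; within the scatter) is expected to be a modest weakening, near the edge of the scatter. Compound 3 is estimated at 90 nM in this assay, ranging from 30 nM to 300 nM.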

Compound 3, half-maximal inhibitory concentration: 220 nM
Compound 3: the middle estimate sits 2.4-fold (0.39 log units) below what was measured; measured number inside the range.
By their numbers in this assay, from the lowest: compound 2; then compounds 1 and 3 (each within the scatter of the next).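

Methyl in place of oxan-4-yl on this amine nitrogen brings a 4.9-fold higher number from compound 2 to compound 3 (0.69 log units; beyond the scatter) and this pair gives the first direct sign that the group on this nitrogen matters, with oxan-4-yl the better of the two. Changing 4-hydroxypiperidin-1-yl to 4-methylpiperazin-1-yl on the aromatic carbon brings a 1.5-fold higher number from compound 1 to compound 3 (0.17 log units; within the scatter) and so does not separate these two groups. Nothing measured here explains the loss seen with methyl. The compounds shown leave open how cyclohexyl, which lacks the ring oxygen of oxan-4-yl, or a short chain such as ethyl would fare on the same nitrogen.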